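Weighing a Dichlorophenyl Swap on a Weakly Active Urea

The source may hold more compounds than are shown below. What is called first, only, known or untested is meant among the compounds shown, and "the series" means these compounds.

The two measured compounds share one core and differ only in the ring carried on the urea nitrogen. Compound 1 `O=C(Nc1ccccc1)Nc1nnc(Sc2ncnc3scc(-c4ccncc4)c23)s1` gives 19400 nM in a functional assay on HepG2 cells (Homo sapiens) for antiproliferative activity, read by MTT assay, with a stated time of 48 h; on this read-out higher numbers stand for weaker inhibition and lower numbers for stronger inhibition; compound 2 `O=C(Nc1ccc(F)cc1)Nc1nnc(Sc2ncnc3scc(-c4ccncc4)c23)s1` gives 31700 nM. The step of a 1.6-fold higher number from compound 1 to compound 2 (0.21 log units; within the scatter) is within the scatter, so the two numbers cannot be told apart. Compound 2 holds the highest of the two numbers shown, with compound 1 its only neighbour at a distance that is within the scatter.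

Compound 3 `O=C(Nc1ccc(Cl)c(Cl)c1)Nc1nnc(Sc2ncnc3scc(-c4ccncc4)c23)s1` follows from compound 2 by 3,4-dichlorophenyl in place of 4-fluorophenyl on an amide-type nitrogen. Within the data shown here, the one measured step, from compound 1 to compound 2, exchanged a hydrogen for a fluorine on the same ring and moved the number within the scatter; no measured step covers a chlorine, let alone two. That step therefore gives no reason to expect movement beyond the scatter in either direction, and the estimate for compound 3 stays close to compound 2: the expected step is a 1.1-fold lower number from compound 2 to compound 3 (0.05 log units; within the scatter). The estimated value for compound 3 is 28000 nM, with a range from 9000 nM to 90000 nM.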

Compound 3, half-maximal inhibitory concentration: 61900 nM
Beside the measured number, compound 3's estimate is 2.2-fold (0.34 log units) below it; measured number inside the range.
By their numbers in this assay, from the lowest: compounds 1, 2 and 3 (each within the scatter of the next, the first and the last beyond it).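

In this assay, among these compounds, the replacement of the bare phenyl by 3,4-dichlorophenyl on the amide-type nitrogen gives a 3.2-fold higher number from compound 1 to compound 3 (0.50 log units; beyond the scatter), the first step at this position to clear the usual variation between repeats, and it is a modest move towards weaker inhibition. Set against 4-fluorophenyl, the same group gives a 2.0-fold higher number from compound 2 to compound 3 (0.29 log units; within the scatter), so compound 2 and compound 3 cannot be told apart, and the change shows up only when the comparison starts from the unsubstituted ring. The position therefore does respond to what the ring carries, but among these three compounds no substituted ring gives a number beyond the scatter on the stronger side of compound 1, so the substituents shown offer no gain in inhibition.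

Nothing available explains this step. From the compounds shown here alone, it also remains open whether a single chlorine would give the same result as two, and whether a ring carrying a methoxy group, an amine or a carboxylic acid, or a longer chain in place of the ring, would bring the numbers down from this weak range.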